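Oxan-2-yl to Oxolan-2-yl: Expected Lipophilicity of Compound 4

The source may report more compounds than this note shows. Statements on the series, on what has been measured and on what is new or still open speak of the compounds shown alone.

Of the compounds shown here, three have been measured in a physicochemical assay for lipophilicity, read by HPLC, measured as octanol-water partition, at pH 7.4; on this read-out higher numbers stand for higher lipophilicity and lower numbers for lower lipophilicity. Compound 1 `CC1(C)CO[C@H]1CN([C@H](CCC(F)(F)F)C(N)=O)S(=O)(=O)c1ccc(Cl)cc1` gives 3.8. Compound 2 `NC(=O)[C@@H](CCC(F)(F)F)N(C[C@H]1CCCCO1)S(=O)(=O)c1ccc(Cl)cc1` gives 4.3, and compound 3 `NC(=O)[C@@H](CCC(F)(F)F)N(C[C@@H]1CCCCO1)S(=O)(=O)c1ccc(Cl)cc1` gives 4.3. Compound 2 therefore stands level with compound 3, and together they sit at the top of the three numbers, while compound 1 lies lowest. Between compounds 2 and 3 there is no change at the digits printed from compound 2 to compound 3 (within the scatter), which fits with the fact that compounds 2 and 3 differ only in the configuration as drawn. Among the compounds with values here, the one step that moves the number is a number 0.50 log units higher from compound 1 to compound 2 (beyond the scatter), which comes with oxan-2-yl in place of 3,3-dimethyloxetan-2-yl on a saturated chain carbon bound to a sulfonamide nitrogen.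

Compound 4 `NC(=O)[C@@H](CCC(F)(F)F)N(C[C@H]1CCCO1)S(=O)(=O)c1ccc(Cl)cc1` has not yet been measured. It differs from compound 2 in one place: oxolan-2-yl in place of oxan-2-yl on a saturated chain carbon bound to a sulfonamide nitrogen. The group that enters is smaller than the group that leaves.

The measured steps give only indirect guidance. The configurational change between compounds 2 and 3 moved nothing, and the step from compound 1 to compound 2 altered ring size and two methyl groups at once, so it does not isolate the effect of ring size alone. A modest fall in this assay is expected, estimated as a number 0.40 log units lower from compound 2 to compound 4 (beyond the scatter). Compound 4 is therefore expected to give 3.9, with a likely range from 3.6 to 4.3.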

Compound 4, distribution coefficient: 3.6
Estimate against measurement, compound 4: 0.30 log units above; the range from low to high includes it.
By their numbers in this assay, from the lowest: compounds 4 and 1 (each within the scatter of the next); then compounds 2 and 3 (each within the scatter of the next).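

On a saturated chain carbon bound to a sulfonamide nitrogen, the effect of ring size can now be read without any other change: in this assay, oxolan-2-yl in place of oxan-2-yl gives a number 0.70 log units lower from compound 2 to compound 4 (beyond the scatter), and the same change gives a number 0.70 log units lower from compound 3 to compound 4 (beyond the scatter). These two steps match in size, and their starting compounds are a close pair: the fact that compounds 2 and 3 differ only in the configuration as drawn. The third new step, a number 0.20 log units lower from compound 1 to compound 4 (within the scatter), means that this assay does not separate oxolan-2-yl from 3,3-dimethyloxetan-2-yl at this position, so among the three ring groups shown, oxan-2-yl alone stands apart, with the higher number.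

The compounds shown leave open whether the oxolan-2-yl group with its ring stereocentre drawn the other way would match compound 4, as compounds 2 and 3 match each other, and how much of the difference between compound 1 and the others comes from the two methyl groups, which a plain oxetan-2-yl group would help to separate. They also leave open whether the ring oxygen matters to these numbers, a question that a cyclopentyl or a piperidin-2-yl group at the same place could address.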